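Carbamate in place of propanamide: expected cytotoxicity of compound 4

The source may report more compounds than this note shows. Statements on the series, on what has been measured and on what is new or still open speak of the compounds shown alone.

Of the compounds shown here, three on a shared core have been tested in an ADME assay on L02 cells (Homo sapiens) for cytotoxicity, read by MTT assay, with a stated time of 48 h; on this read-out higher numbers stand for weaker inhibition and lower numbers for stronger inhibition. Compound 1 `O=C1CNC(=O)N1C[C@H]1CN(c2ccc(-n3cc(-c4ccccn4)cn3)c(F)c2)C(=O)O1` gives only a limit of the assay, > 400 ug/mL. Compound 2 `COC[C@H]1CN(c2ccc(-n3cc(-c4ccccn4)cn3)c(F)c2)C(=O)O1` likewise gives only a limit, > 400 ug/mL. Among the measured compounds shown here, compound 3 `CCC(=O)NC[C@H]1CN(c2ccc(-n3cc(-c4ccccn4)cn3)c(F)c2)C(=O)O1` is the one compound with a number, 204 ug/mL. The step that the two limits leave unreadable from compound 1 to compound 2 cannot be read, as both ends sit at the limit of > 400 ug/mL in this assay, at which 2 of the 3 values shown sit. The steps of an at least 1.9-fold lower number from compound 1 to compound 3 (0.29 log units; that floor lies within the scatter) and an at least 1.9-fold lower number from compound 2 to compound 3 (0.29 log units; that floor lies within the scatter) each have a floor that lies within the scatter, so they do not establish a change beyond it.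

Compound 4 `COC(=O)NC[C@H]1CN(c2ccc(-n3cc(-c4ccccn4)cn3)c(F)c2)C(=O)O1` differs from compound 3 by methoxy in place of ethyl on a carbonyl carbon. For the measured compounds named here, none of the measured steps alters this place; they all exchange the whole group on the chain carbon. Going by the values given here, no measured step therefore points to a change beyond the scatter in this assay, and compound 4 is expected to give a number close to that of compound 3, with the step of a 1.4-fold higher number from compound 3 to compound 4 (0.14 log units; within the scatter) estimated as within the scatter. Compound 4 is thus estimated at 280 ug/mL, ranging from 140 ug/mL to 560 ug/mL.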

Compound 4, half-maximal inhibitory concentration: 71 ug/mL
The estimate for compound 4 lay 3.9-fold (0.60 log units) above the measured number; the whole stated range lies above it.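

In this assay, the carbonyl carbon of the side chain proves to be a place that matters: with methoxy in place of ethyl, the result is a 2.9-fold lower number from compound 3 to compound 4 (0.46 log units; beyond the scatter). Among the compounds shown here, none of the earlier steps on the shared core had been established as a change beyond the scatter. Against the two compounds with only a limit, (methoxycarbonyl)amino gives an at least 5.6-fold lower number from compound 2 to compound 4 (0.75 log units; beyond the scatter) and an at least 5.6-fold lower number from compound 1 to compound 4 (0.75 log units; beyond the scatter), and both sizes are floors, not exact steps: the limit of > 400 ug/mL in this assay, at which 2 of the 4 values shown sit.

The compounds shown leave open whether the lower number belongs to methoxy alone or extends to other groups on this carbonyl carbon, such as methyl, methylamino or ethoxy. On these data alone, how the number moves with a longer chain on the carbamate oxygen also remains open.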